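Ethoxycarbonyl added on the sulfanyl methyl of compound 3

The compounds below may be only part of what the source reports. "The series", "measured", "known", "first", "only" and "open" are said of these compounds alone.

Measured compounds:
compound 1 `COc1ccc(-n2c(SC)nnc2-c2cc(OC)c(OC)c(OC)c2)cc1` gives > 60000 nM in a functional assay on HT-29 cells (Homo sapiens) for inhibition, read by MTT assay, with a stated time of 48 h; a higher number here means a weaker inhibitor, a lower number a stronger inhibitor
compound 2 `COc1ccc(C(=O)CSc2nnc(-c3cc(OC)c(OC)c(OC)c3)n2-c2ccc(OC)cc2)cc1` gives > 60000 nM
compound 3 `COc1cc(-c2nnc(SC)n2-c2ccc(N(C)C)cc2)cc(OC)c1OC` gives > 60000 nM

Each of these three values is a limit of the assay and not a number. All three therefore sit at the limit of > 60000 nM in this assay, at which 3 of the 3 values shown sit. Two steps connect them. The step that the two limits leave unreadable from compound 1 to compound 2 puts (4-methoxyphenyl)carbonyl in place of hydrogen on a saturated chain carbon bound to a sulfur. The step that the two limits leave unreadable from compound 1 to compound 3 puts dimethylamino in place of methoxy on an aromatic carbon. Neither step can be sized; both of its ends are limits.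

Compound 3 thus stands at the limit, as do the two other values shown. Compound 4 `CCOC(=O)CSc1nnc(-c2cc(OC)c(OC)c(OC)c2)n1-c1ccc(N(C)C)cc1` has not yet been measured. It differs from compound 3 in one place: ethoxycarbonyl in place of hydrogen on a saturated chain carbon bound to a sulfur. For the measured compounds named here, the only measured step that touches the same saturated chain carbon bound to a sulfur is the one from compound 1 to compound 2, and that step is unreadable, so no size in either direction can be read from the data for this change. The step that the limit leaves unreadable from compound 3 to compound 4 is accordingly expected to stay below anything that can be told from the scatter. Compound 4 is expected to give about 80000 nM, in a range of 20000 nM to 300000 nM, most probably reported once more as a limit.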

Compound 4, half-maximal inhibitory concentration: 28800 nM
Compound 4: the middle estimate sits 2.8-fold (0.44 log units) above what was measured, within the range that was stated.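

In this assay, ethoxycarbonyl in place of hydrogen on a saturated chain carbon bound to a sulfur brings an at least 2.0-fold lower number from compound 3 to compound 4 (0.31 log units; beyond the scatter), and compound 3 stands at a limit, so the true size of this step may be larger. The earlier steps shown here cannot be read, including the one that put (4-methoxyphenyl)carbonyl on this same carbon, which makes this the first sign that a group added here can change the value. Compound 4 is also the only one shown with a number and not a limit: the limit of > 60000 nM in this assay, at which 3 of the 4 values shown sit.

The compounds shown leave open whether ethoxycarbonyl has the same effect with methoxy in place of dimethylamino, since it appears here only alongside dimethylamino. They also leave open what a carboxylic acid or a longer chain in place of the ethoxycarbonyl would give on this carbon.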